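The source may report more compounds than this note shows. Statements on the series, on what has been measured and on what is new or still open speak of the compounds shown alone.

Measured so far in a physicochemical assay for solubility, at pH 7.4; on this read-out lower numbers stand for lower solubility and higher numbers for higher solubility:

- compound 1, `CN1CCN(c2ccccc2C(=O)/C=C/c2ccc(/C=C/C(=O)NO)cc2)CC1`: 210000 nM
- compound 2, `O=C(/C=C/c1ccc(/C=C/C(=O)c2ccccc2)cn1)NO`: 27000 nM
- compound 3, `CN1CCN(c2ccc(C(=O)/C=C/c3cccc(/C=C/C(=O)NO)c3)cc2)CC1`: 15000 nM

Compound 1 stands highest of the three numbers in this assay. Its nearest neighbour is compound 2, whose value is lower by a margin beyond the usual scatter, and compound 3 lies further below still, also beyond the scatter. No two of these compounds differ in only one place, so no single structural step among the measured values can be read off directly.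

Compound 4, `O=C(/C=C/c1ccc(/C=C/C(=O)c2ccccc2)cc1)NO`, has not yet been measured in this assay. It is derived from compound 1 by one change: hydrogen in place of 4-methylpiperazin-1-yl on an aromatic carbon. Of the measured compounds, compound 2 is the one that likewise carries no 4-methylpiperazin-1-yl, and compound 2 gives 27000 nM in this assay, a considerably lower number than compound 1.

On that basis the step is expected to go downward, and to be large rather than within the scatter: the estimated change is a 26-fold lower number from compound 1 to compound 4 (1.42 log units; beyond the scatter). For compound 4 the expected value in this assay is 8000 nM, within a range from 2000 nM to 30000 nM.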

Compound 4, solubility: 3000 nM
Beside the measured number, compound 4's estimate is 2.7-fold (0.43 log units) above it, within the range that was stated.
By their numbers in this assay, from the lowest: compound 4; then compounds 3 and 2 (each within the scatter of the next); then compound 1.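

For the compounds shown here, replacing 4-methylpiperazin-1-yl with hydrogen on this aromatic carbon, ortho to a large group, gives a 70-fold lower number from compound 1 to compound 4 (1.85 log units; beyond the scatter) in this assay and is the only single-place comparison available. The earlier compounds shown here differed in more than one place, so they could not separate this change from the others; now its effect at this position can be read directly, and the step is large and beyond the scatter. Nothing presented here accounts for the size of this step.

Going by these compounds, it remains open whether another group on the same aromatic carbon, such as a morpholine ring or a dimethylamino group, would give a number nearer to that of compound 1 or to that of compound 4. On these data alone, it is also open whether moving 4-methylpiperazin-1-yl to another carbon of this ring, with the rest of compound 1 unchanged, would alter the number.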